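A few compounds are considered here, and "the series" means these few. Any claim that something is new, unique, unknown or untested is made for them only; others in the source may bear on it.

Measured so far in a functional assay on T47D cells (Homo sapiens) for cytotoxicity, read by MTT assay, with a stated time of 2 days; on this read-out higher numbers stand for weaker inhibition and lower numbers for stronger inhibition:
Compound 1 `Cc1cccc(-c2nc3cc(C)ccc3c(=O)[nH]2)c1`: > 50000 nM, a limit
Compound 2 `COc1cccc(-c2nc3cc(C)ccc3c(=O)[nH]2)c1`: > 50000 nM, a limit

Neither entry is a number, so compound 2 has no exact place in this short series. What the two compounds have in common is the limit of > 50000 nM in this assay, at which 2 of the 2 values shown sit.

Compound 3 `Cc1ccc2c(=O)[nH]c(-c3cccc(OC(F)(F)F)c3)nc2c1` keeps the shared core and alters a single group: trifluoromethyl in place of methyl on an oxygen on an aromatic ring. Put another way, the change is methoxy to trifluoromethoxy, with trifluoromethyl in place of methyl on an oxygen on an aromatic ring.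

Among the measured compounds shown here, only one measured step bears on this change: a step that the two limits leave unreadable from compound 1 to compound 2. That step replaced methyl with methoxy on an aromatic carbon, and it gives no size that could be carried over. For the measured compounds named here, no definite step is therefore expected in this assay, in either direction. The likeliest outcome is that compound 3 will also be reported only as a limit, and any number that does appear is expected to lie close to that limit. The estimate for compound 3 is 50000 nM, with an expected range from 20000 nM to 100000 nM. The expected step is a number no higher from compound 2 to compound 3 (the limit leaves the size open).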

Compound 3, half-maximal inhibitory concentration: > 50000 nM
Compound 3: a limit, no number (the forecaster's own chance of this, stated with the estimate: 75%); the middle value sits exactly at the limit.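

No step can be read among compound 1, compound 2 and compound 3 in this assay, because each of the three is reported only as a limit and not as a number: the limit of > 50000 nM in this assay, at which 3 of the 3 values shown sit.

The compounds shown leave open whether methyl, methoxy and trifluoromethoxy differ at all in this read-out, and how large any such difference would be.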